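The source may hold more compounds than are shown below. What is called first, only, known or untested is meant among the compounds shown, and "the series" means these compounds.

Compound 1 `CCCCCCCCCCc1ccc(-c2noc(C3CCNC3)n2)cc1`: 26%
Compound 2 `CCCCCCCCCCc1ccc(-c2noc(CN3CCNCC3)n2)cc1`: 19%
Compound 3 `CCCCCCCCCCc1ccc(-c2noc([C@H]3CCC[C@@H](N)C3)n2)cc1`: 29%

In an assay on HeLa cells for inhibition of sphingosine-1-phosphate transporter SPNS2 (Mus musculus), read by LC-MS, tested at 2 uM (a higher number here means more inhibition at the concentration tested (going by the name of the read-out), a lower number less inhibition), compound 3 has the highest of the three numbers, yet its steps to the other two are both within the scatter: a number 3 percentage points higher from compound 1 to compound 3 (within the scatter) and a number 10 percentage points higher from compound 2 to compound 3 (within the scatter). Compound 4 `CCCCCCCCCCc1ccc(-c2noc([C@@H](N)CCCN)n2)cc1` has not yet been measured. Its change from compound 3 is 1,4-diaminobutyl in place of 3-aminocyclohexyl on an aromatic carbon. All three measured steps swap one amine-bearing group for another at this same aromatic carbon, and none leaves the scatter, including a number 7 percentage points lower from compound 1 to compound 2 (within the scatter). The measured steps therefore point to no step beyond the scatter in this assay in either direction. For compound 4 the expected value is 25%, with a range from 10% to 42%. This estimate means a step of a number 4 percentage points lower from compound 3 to compound 4 (within the scatter).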

Compound 4, a percentage reported as inhibition, at one concentration (the size of the read-out at that concentration, not a potency): 40%
Beside the measured number, compound 4's estimate is 15 percentage points below it, within the range that was stated.
By their numbers in this assay, from the lowest: compounds 2, 1 and 3 (each within the scatter of the next); then compound 4.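

In this assay this aromatic carbon can carry a change that leaves the scatter: 1,4-diaminobutyl, which has no ring, gives a number 11 percentage points higher from compound 3 to compound 4 (beyond the scatter) and a number 21 percentage points higher from compound 2 to compound 4 (beyond the scatter) and a number 14 percentage points higher from compound 1 to compound 4 (beyond the scatter) as well. The position is therefore not indifferent to which amine-bearing group it holds, though all three steps are modest. Nothing measured here explains the rise.

From the compounds shown here alone, this change removes the ring and adds an amine together, so the two effects cannot be told apart. 4-Aminobutyl, with a single amine on an open chain, would separate them, and whether a longer chain such as 1,5-diaminopentyl goes further stays open.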